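The compounds below may be only part of what the source reports. "The series", "measured", "known", "first", "only" and "open" are said of these compounds alone.

Series notes. Compound 1 `CCCCCC[C@H]1C[C@@H](O)[C@@H](O)C1` in an ADME assay on S2 cells (Drosophila melanogaster) for cytotoxicity, read by MTT assay (a lower number here means that less compound is needed, a higher number that more compound is needed for the effect), gives 110000 nM. Compound 2 `CN(C)C(=O)/C=C/[C@H]1C[C@@H](O)[C@@H](O)C1` reaches only the limit of this assay, > 250000 nM, so for compound 2 no number is known, as marked by the limit of > 250000 nM in this assay, at which 1 of the 2 values shown sits. Compound 3 `O=C(O)/C=C/[C@H]1C[C@@H](O)[C@@H](O)C1` carries hydroxy in place of dimethylamino on a carbonyl carbon. Among the compounds with values here, with one of the two values a limit and no step between measured compounds known, no size of step in this assay can be read from these compounds. Compound 3 is expected to stand at the limit again, an expected step that the limit leaves unreadable from compound 2 to compound 3. The estimate for compound 3 in this assay is 300000 nM, ranging from 150000 nM to 1000000 nM.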

Compound 3, half-maximal effective concentration: > 350000 nM
Compound 3: a limit, no number (the forecaster's own chance of this, stated with the estimate: 70%); middle value at least 1.1-fold (0.06 log units) from the limit.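

Within the data shown here, compound 2 and compound 3 both stand at limits in this assay, and no step between them can be read. The compounds shown leave open what hydroxy in place of dimethylamino on a carbonyl carbon does to the value.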